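This account rests on a few compounds, and the source may have more. Where it says the series, first, only, none or still open, it means among the compounds named here.

Measured compounds:
- compound 1, `Cc1ccc2nc(C)n(NC(=O)CC#N)c(=O)c2c1`: in a functional assay on HepG2 cells (Homo sapiens) for cytotoxicity, read by MTT assay, with a stated time of 3 days (on this read-out higher numbers stand for weaker inhibition and lower numbers for stronger inhibition), compound 1 gives 55000 nM
- compound 2, `Cc1ccc2nc(C)n(NC(=O)/C(C#N)=C/c3ccc(Cl)cc3)c(=O)c2c1`: compound 2 gives 9000 nM
- compound 3, `Cc1ccc2nc(C)n(NC(=O)/C(C#N)=C/c3ccc([N+](=O)[O-])cc3)c(=O)c2c1`: compound 3 gives 10000 nM

Compound 2 has the lowest number of the three in this assay, but compound 3 sits within the scatter of it, so the two cannot be separated; only compound 1 stands clearly apart, with the higher number.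

The step under consideration leads from compound 2 to compound 4, `Cc1ccc2nc(C)n(NC(=O)/C(C#N)=C/c3ccc(O)cc3)c(=O)c2c1`, which has not yet been measured in this assay. The change is hydroxy in place of chloro on an aromatic carbon.

Going by the values given here, only one measured step bears on this change, and only loosely: from compound 2 to compound 3 the same position carries a nitro group in place of the chloro group, and the result was a 1.1-fold higher number from compound 2 to compound 3 (0.05 log units; within the scatter). That one exchange at this position left the number essentially where it was. Among the compounds with values here, no measured pair shows a hydroxy group anywhere, so there is nothing direct to go on.

On that basis a step of no real size beyond the scatter is expected, with a slight lean toward a higher number; the expected step is a 1.3-fold higher number from compound 2 to compound 4 (0.12 log units; within the scatter). Compound 4 is therefore estimated at 12000 nM, with a range from 5000 nM to 35000 nM.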

Compound 4, half-maximal inhibitory concentration: 13000 nM
For compound 4 the middle estimate is 1.1-fold (0.03 log units) below the measured one; the range from low to high includes it.
By their numbers in this assay, from the lowest: compounds 2, 3 and 4 (each within the scatter of the next); then compound 1.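

In this assay, hydroxy in place of chloro on the aromatic carbon gives a 1.4-fold higher number from compound 2 to compound 4 (0.16 log units; within the scatter) and hydroxy in place of nitro gives a 1.3-fold higher number from compound 3 to compound 4 (0.11 log units; within the scatter) with neither exchange leaving the scatter. Going by these compounds alone, this adds a second and a third exchange at this position to the single one known before, and the entering hydroxy is the first group here counted with a hydrogen-bond donor, whereas chloro has none, yet that difference comes with no step beyond the scatter. Compound 2, compound 3 and compound 4 therefore cannot be separated from one another in this assay, and nothing available explains why the number is so little affected by these exchanges.

The compounds shown leave open whether this insensitivity extends to other groups at the same place, such as an amine, a carboxylic acid, a methoxy group or a longer chain, or to a plain phenyl ring with only hydrogen there. They also leave open whether chloro or hydroxy would behave the same way on any other carbon of the ring, since every aromatic group compared here is substituted para to the large group.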